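The compounds below may be only part of what the source reports. "The series", "measured", "known", "first", "only" and "open" are said of these compounds alone.

Of the compounds shown here, three built on a shared core have been tested in a functional assay on HEK293 cells (Homo sapiens) for cytotoxicity; a lower number here means that less compound is tolerated, a higher number that more compound is tolerated. Compound 1, `COc1ccc([C@H]2CC(=O)N(c3cccc(C#N)c3)C2)cc1OC1CCCC1`, carries a nitrile on one of its aromatic rings. In this assay compound 1 gives > 10000 nM, which is a limit of the assay rather than a number. Compound 2, `CCCCNc1cccc(N2C[C@@H](c3ccc(OC)c(OC4CCCC4)c3)CC2=O)c1`, differs from it in one place, with a butylamino in place of cyano on an aromatic carbon. In this assay compound 2 gives > 10000 nM, again a limit and not a number. The step that the two limits leave unreadable from compound 1 to compound 2 is accordingly unreadable. Compound 3, `COc1ccc([C@H]2CC(=O)N(c3cccc(NS(=O)(=O)c4cccc(OC(F)(F)F)c4)c3)C2)cc1OC1CCCC1`, carries a sulfonamide bearing a 3-(trifluoromethoxy)phenyl group. In this assay compound 3 gives > 10000 nM, also a limit and not a number. Going by the values given here, compound 3 thus stands where all values so far sit, at the limit of > 10000 nM in this assay, at which 3 of the 3 values shown sit. Compound 4, `COc1ccc([C@H]2CC(=O)N(c3cccc(NS(=O)(=O)c4ccccc4Br)c3)C2)cc1OC1CCCC1`, differs from compound 3 in one place: 2-bromophenyl in place of 3-(trifluoromethoxy)phenyl on a sulfonyl sulfur. Among the compounds with values here, no measured step bears on this change; the only step between measured compounds is unreadable and concerns a different position. For compound 4 in this assay the step that the limit leaves unreadable from compound 3 to compound 4 is expected to be none beyond the scatter. Compound 4 is estimated at 20000 nM, with a range from 8000 nM to 100000 nM, and most likely another limit.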

Compound 4, half-maximal cytotoxic concentration: > 10000 nM
Compound 4: only a limit was reported (the forecaster's own chance of this, stated with the estimate: 85%); the middle value does not contradict the limit.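

In this assay compound 4 gives > 10000 nM, a limit and not a number. Its steps from compound 1, compound 2 and compound 3 cannot be read, because all four compounds share one limit: the limit of > 10000 nM in this assay, at which 4 of the 4 values shown sit.

The compounds shown leave open whether any change on the shared core alters the concentration tolerated in this assay.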